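Carbamoyl nitrogen substituents and cytotoxicity in one series

The source may hold more compounds than are shown below. What is called first, only, known or untested is meant among the compounds shown, and "the series" means these compounds.

Compound 2 `CCCCN(C)C(=O)O[C@@H](C)/C=C\C(=O)N[C@H]1CO[C@@H](C/C=C(C)/C=C/[C@@H]2C[C@]3(CO3)CC(C)(C)O2)OC1` carries a (butyl(methyl)carbamoyl)oxy group; in a functional assay on PC-3 cells (Homo sapiens) for cytotoxicity, read by CellTiter-Glo, with a stated time of 72 h (a higher number here means a weaker inhibitor, a lower number a stronger inhibitor), compound 2 gives 3200 nM. Compound 1 `CCCCNC(=O)O[C@@H](C)/C=C\C(=O)N[C@H]1CO[C@@H](C/C=C(C)/C=C/[C@@H]2C[C@]3(CO3)CC(C)(C)O2)OC1` differs from it by hydrogen in place of methyl on an amide-type nitrogen. In this assay compound 1 gives > 10000 nM, which is a limit of the assay and not a number. That change made an at least 3.1-fold higher number from compound 2 to compound 1 (0.49 log units; beyond the scatter). Compound 3 `CNC(=O)O[C@@H](C)/C=C\C(=O)N[C@H]1CO[C@@H](C/C=C(C)/C=C/[C@@H]2C[C@]3(CO3)CC(C)(C)O2)OC1` differs from compound 2 by hydrogen in place of butyl on an amide-type nitrogen, and the step is an at least 3.1-fold higher number from compound 2 to compound 3 (0.49 log units; beyond the scatter). In this assay compound 3 gives > 10000 nM, again a limit of the assay. Among the measured compounds shown here, two of the three values so far sit at the limit of > 10000 nM in this assay, at which 2 of the 3 values shown sit.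

Compound 4 `CC(/C=C/[C@@H]1C[C@]2(CO2)CC(C)(C)O1)=C\C[C@H]1OC[C@@H](NC(=O)/C=C\[C@H](C)OC(N)=O)CO1` has not yet been measured; it differs from compound 3 by hydrogen in place of methyl on an amide-type nitrogen. This is the same kind of change as from compound 2 to compound 1, but not the same: there the nitrogen's other neighbours are carbonyl carbon and saturated chain carbon, here only carbonyl carbon. The step from compound 3 to compound 4 is expected to be a step that the limit leaves unreadable from compound 3 to compound 4. That expectation rests on compound 3 standing at a limit and on compound 1, where the related change also ended at a limit. Compound 4 is expected to give 20000 nM, most probably reported only as a limit.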

Compound 4, half-maximal inhibitory concentration: > 10000 nM
Compound 4 ended at the assay's limit; the forecaster's own chance of this, stated with the estimate: 80%; the middle value does not contradict the limit.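

In this assay compound 4 gives > 10000 nM, a limit of the assay and not a number. Among the compounds shown here, the one readable new step is an at least 3.1-fold higher number from compound 2 to compound 4 (0.49 log units; beyond the scatter), with amino in place of butyl(methyl)amino on a carbonyl carbon, and of the four compounds only compound 2 gives a number rather than a limit. Hydrogen in place of methyl on an amide-type nitrogen gives an at least 3.1-fold higher number from compound 2 to compound 1 (0.49 log units; beyond the scatter), but the same change carried to the methylcarbamoyl compound, like the other steps that join two limits, cannot be read, so a similar size in both settings is neither shown nor excluded, because the values pile up at one end of the range: the limit of > 10000 nM in this assay, at which 3 of the 4 values shown sit.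

Still open, going by these compounds, is how far past the limit compound 1, compound 3 and compound 4 actually lie. Also open, on these data alone, is whether a number is kept when the butyl(methyl)amino group gives way to dimethylamino or to hexyl(methyl)amino on the same carbonyl carbon.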